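Replacing the aryl methyl by phenyl in a chalcone series

The source may report more compounds than this note shows. Statements on the series, on what has been measured and on what is new or still open speak of the compounds shown alone.

Measured so far:
compound 1 `COc1ccc(/C=C/c2cc(OC)cc(OC)c2/C=C/C(=O)c2ccc(C)cc2)cc1` — 5.3 ug/mL
compound 2 `CCCCCCOc1ccc(C(=O)/C=C/c2c(/C=C/c3ccc(OC)cc3)cc(OC)cc2OC)cc1` — 10.4 ug/mL
compound 3 `COc1ccc(/C=C/c2cc(OC)cc(OC)c2/C=C/C(=O)c2ccccc2C)cc1` — 6.1 ug/mL

In a functional assay on B16-F10 cells (Mus musculus) for antiproliferative activity, read by MTT assay, with a stated time of 48 h (a higher number here means a weaker inhibitor, a lower number a stronger inhibitor), compound 1 gives the lowest of the three numbers, but its steps to the others, a 2.0-fold higher number from compound 1 to compound 2 (0.29 log units; within the scatter) and a 1.2-fold higher number from compound 1 to compound 3 (0.06 log units; within the scatter), both lie within the scatter, so no order among compounds 1, 2 and 3 can be claimed. Compound 4 `COc1ccc(/C=C/c2cc(OC)cc(OC)c2/C=C/C(=O)c2ccc(-c3ccccc3)cc2)cc1` differs from compound 1 by phenyl in place of methyl on an aromatic carbon. Among the measured compounds shown here, the one measured step that bears on this change is a 2.0-fold higher number from compound 1 to compound 2 (0.29 log units; within the scatter), where a larger group enters on the same aromatic carbon without moving the number beyond the scatter. The same outcome is expected here: for compound 4 the estimated step of a 1.3-fold higher number from compound 1 to compound 4 (0.12 log units; within the scatter) is expected to stay within the scatter. Compound 4 is thus expected to give 7 ug/mL, in the range 3.5 ug/mL to 14 ug/mL.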

Compound 4, half-maximal inhibitory concentration: 10.6 ug/mL
Beside the measured number, compound 4's estimate is 1.5-fold (0.18 log units) below it, and the stated range covers the measured number.
By their numbers in this assay, from the lowest: compounds 1, 3, 2 and 4 (each within the scatter of the next).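

In this assay the change to phenyl gives a 2.0-fold higher number from compound 1 to compound 4 (0.30 log units; within the scatter) and so an aromatic ring on this carbon, like the hexyloxy chain, leaves the number within the scatter. The two larger groups cannot be told apart, with a 1.0-fold higher number from compound 2 to compound 4 (0.01 log units; within the scatter) as their step, and 4-phenylphenyl against 2-methylphenyl gives a 1.7-fold higher number from compound 3 to compound 4 (0.24 log units; within the scatter) as well.

Whether an amine or a carboxylic acid on this carbon would step beyond the scatter stays open, as no step shown does so. Nothing available explains these numbers.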